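The source may report more compounds than this note shows. Statements on the series, on what has been measured and on what is new or still open speak of the compounds shown alone.

Compound 2 `COc1ccc(-c2cnc(NC(=O)c3cccc(C#N)c3)n2C)cc1` was tested in a toxicity assay on THP-1 cells (Homo sapiens) for inhibition; on this read-out lower numbers stand for higher toxicity in this test and higher numbers for lower toxicity in this test. In this assay compound 2 reaches only the limit > 100000 nM, a limit of the measurement rather than a number. For the measured compounds named here, compound 1 `CCC(=O)Nc1ncc(-c2ccc(OC)cc2)n1C` is the one measured neighbour that differs from compound 2 in a single place. In this assay compound 1 likewise gives only the limit > 100000 nM, again a limit and not a number. The step between them, a step that the two limits leave unreadable from compound 1 to compound 2, therefore cannot be read in size, since both ends sit at the same edge of the measurement; this is summed up by the limit of > 100000 nM in this assay, at which 2 of the 2 values shown sit.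

Compound 3 `COc1ccc(-c2cnc(NC(C)=O)n2C)cc1` is the unmeasured compound of interest. It differs from compound 2 by methyl in place of 3-cyanophenyl on a carbonyl carbon. No measured step in this series speaks to this change with a readable size, because the limit of > 100000 nM in this assay, at which 2 of the 2 values shown sit, shows both shown values resting at the limit. Compound 3 is thus expected to show a step that the limit leaves unreadable from compound 2 to compound 3, that is, nothing beyond the usual scatter, and most likely another limit. The estimate for compound 3 in this assay is 150000 nM, with a range from 60000 nM to 400000 nM.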

Compound 3, half-maximal cytotoxic concentration: > 100000 nM
Compound 3: no number, only a limit (the forecaster's own chance of this, stated with the estimate: 80%); the middle value is on the limit's open side.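

In this assay, for the compounds shown here, compound 3 also ends at a limit rather than a number, so no step among compound 1, compound 2 and compound 3 can be read in size: the limit of > 100000 nM in this assay, at which 3 of the 3 values shown sit. The compounds shown leave open whether any group on the carbonyl carbon would give a readable toxicity number on these cells.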